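Diarylamine in Place of a Benzyl Ether on an Inactive Core

The compounds below may be only part of what the source reports. "The series", "measured", "known", "first", "only" and "open" are said of these compounds alone.

In a functional assay on Raji cells (Homo sapiens) for cytotoxicity, with a stated time of 72 h (a higher number here means that more compound is needed for the effect, a lower number that less compound is needed), compound 1 `C=C[C@@](C)(/C=C/c1ccc(OCc2ccccc2)cc1)CCC=C(C)C` reaches only the limit of the assay, > 26000 nM. Compound 2 `C=C[C@@](C)(/C=C/c1ccc(O)cc1)CC/C=C(\C)C=O` likewise gives only a limit, > 26000 nM. Compound 3 `CC(C)=CCC[C@@](C)(/C=C/c1ccccc1)/C=C/c1ccc(O)cc1` also stops at a limit, > 26000 nM. Among the measured compounds shown here, none of the three therefore has a measured number; all sit at the limit of > 26000 nM in this assay, at which 3 of the 3 values shown sit, so no step between measured compounds can be told, and compound 1 cannot be ranked against the others.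

Compound 4 `C=C[C@@](C)(/C=C/c1ccc(Nc2ccc(Cl)cc2)cc1)CCC=C(C)C` differs from compound 1 by (4-chlorophenyl)amino in place of benzyloxy on an aromatic carbon. Whether this change moves cytotoxicity beyond the scatter cannot be read from compounds that all sit at a limit. Compound 4 is expected to give about 30000 nM, in the range 5000 nM to 100000 nM. The step that the limit leaves unreadable from compound 1 to compound 4 is thus expected to stay within the scatter, most likely ending again at a limit.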

Compound 4, half-maximal effective concentration: > 26000 nM
Compound 4 gave a limit, no number; the forecaster's own chance of this, stated with the estimate: 70%; the middle value lies beyond the limit too.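

Compound 1 and compound 4 both stop at a limit, so no step can be read between them: the limit of > 26000 nM in this assay, at which 4 of the 4 values shown sit.

The compounds shown leave open whether (4-chlorophenyl)amino in place of benzyloxy changes the outcome in this assay at all.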